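One Aromatic Group Swapped: Expecting Compound 4

The compounds below may be only part of what the source reports. "The series", "measured", "known", "first", "only" and "open" are said of these compounds alone.

Three compounds have been measured in a functional assay on JAR cells (Homo sapiens) for inhibition, read by MTT assay, with a stated time of 72 h, tested at 10 uM; on this read-out higher numbers stand for more inhibition at the one concentration tested (going by the name of the read-out) and lower numbers for less inhibition:
Compound 1, `CCOC(=O)C1=C(Nc2ccccc2)S/C(=C\c2ccc(O)c(O)c2)C1=O`, gives 48.7%.
Compound 2, `CCOC(=O)C1=C(Nc2cccc(F)c2)S/C(=C\c2ccc[nH]2)C1=O`, gives 45.4%.
Compound 3, `CCOC(=O)C1=C(Nc2ccccc2)S/C(=C\c2ccc(C(=O)OCC)[nH]2)C1=O`, gives 60.1%.

Compound 1 stands second highest of these three numbers. Its nearest neighbour is compound 2, whose value lies a little lower, within the usual scatter of repeated measurements; its furthest is compound 3, whose value lies higher by an amount beyond that scatter.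

Compound 4, `CCOC(=O)C1=C(Nc2ccccc2)S/C(=C\c2cc3cnccc3[nH]2)C1=O`, has not yet been measured. It differs from compound 1 in one place:
a group of 9 heavy atoms (7 carbon, 2 nitrogen; one five-membered aromatic ring with 1 hetero atom, one six-membered aromatic ring with 1 hetero atom) in place of a group of 8 heavy atoms (6 carbon, 2 oxygen; one six-membered aromatic ring of carbon only), on a double-bonded chain carbon bound to a double-bonded ring carbon
So the 3,4-dihydroxyphenyl group leaves, and a group with one five-membered aromatic ring with one hetero atom and one six-membered aromatic ring with one hetero atom enters on the double-bonded chain carbon bound to a double-bonded ring carbon.

Among the compounds with values here, no step between two measured compounds shows what such a swap does. The expectation for compound 4 is a step of about a number 3.3 percentage points higher from compound 1 to compound 4 (within the scatter), within the scatter, in no firm direction. Compound 4 is estimated at 52%, between 38% and 66%.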

Compound 4, a percentage reported as inhibition, at one concentration (the size of the read-out at that concentration, not a potency): < 10%
Compound 4 was reported as a limit; the forecaster's own chance of this, stated with the estimate: 0%; at least 42 percentage points between middle value and limit.
By their numbers in this assay, from the lowest: compounds 2 and 1 (each within the scatter of the next); then compound 3. At a limit, below all of these: compound 4.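

At this place, on the double-bonded chain carbon bound to a double-bonded ring carbon, the group cannot be exchanged freely in this assay. Replacing 3,4-dihydroxyphenyl with the group carrying one five-membered and one six-membered aromatic ring, each with one hetero atom, gives a number at least 38.7 percentage points lower from compound 1 to compound 4 (beyond the scatter). The result for compound 4 is a limit and not a number, the first such result among the compounds shown: the limit of < 10% in this assay, at which 1 of the 4 values shown sits.

The compounds shown leave open which part of this swap matters, whether the departure of the two hydroxyl groups or the arrival of the two-ring group with its nitrogen atoms. A plain phenyl group or a single-ring pyridine at this place could help separate the two, and neither is among these compounds.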